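Moving a Fluorine on the Amide Ring: Compound 4

The source may report more compounds than this note shows. Statements on the series, on what has been measured and on what is new or still open speak of the compounds shown alone.

Of the compounds shown here, three sharing one core have been measured in a functional assay on Ramos cells (Homo sapiens) for antiproliferative activity, read by CCK-8 assay, with a stated time of 72 h; on this read-out lower numbers stand for stronger inhibition and higher numbers for weaker inhibition. Compound 1 `CCOC(=O)c1sc(-c2cccc(NC(=O)c3cccc(F)c3)c2)nc1Nc1ccc(N2CCN(C)CC2)cc1` gives 12800 nM. Compound 2 `CCOC(=O)c1sc(-c2cccc(NC(=O)c3ccccc3F)c2)nc1Nc1ccc(N2CCN(C)CC2)cc1` gives 2000 nM in this assay. Compound 3 `CN1CCN(c2ccc(Nc3nc(-c4cccc(NC(=O)c5cccc(F)c5)c4)sc3C(=O)O)cc2)CC1` gives 14000 nM in this assay.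

Compound 2 differs from compound 1 by a single change, (2-fluorophenyl in place of 3-fluorophenyl on a carbonyl carbon), and this change produced a 6.4-fold lower number from compound 1 to compound 2 (0.81 log units; beyond the scatter). Compound 3 differs from compound 1 in its core only: hydrogen in place of ethyl on an oxygen next to a carbonyl group. That change produced a 1.1-fold higher number from compound 1 to compound 3 (0.04 log units; within the scatter), so the two cores behave alike on this read-out.

Compound 4 `CN1CCN(c2ccc(Nc3nc(-c4cccc(NC(=O)c5ccccc5F)c4)sc3C(=O)O)cc2)CC1` has not yet been measured. It stands to compound 3 exactly as compound 2 stands to compound 1: the change is 2-fluorophenyl in place of 3-fluorophenyl on a carbonyl carbon, made at the same place, so the same change appears here a second time, now on the core that carries a carboxy group instead of an ethoxycarbonyl group.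

The expected step is a 5.6-fold lower number from compound 3 to compound 4 (0.75 log units; beyond the scatter), because a 6.4-fold lower number from compound 1 to compound 2 (0.81 log units; beyond the scatter) was observed when this same change was made on the other core. Among the measured compounds shown here, with only one earlier instance of the change to rest on, the range is kept wide. For compound 4 the estimate in this assay is 2500 nM, with a likely span from 800 nM to 8000 nM.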

Compound 4, half-maximal inhibitory concentration: 6300 nM
Estimate against measurement, compound 4: 2.5-fold (0.40 log units) below; measured number inside the range.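

In this assay, 2-fluorophenyl in place of 3-fluorophenyl gives a 2.2-fold lower number from compound 3 to compound 4 (0.35 log units; beyond the scatter), so the direction of the change carries over to the core with the carboxy group, but its size does not: the same change on two cores in this assay, a 6.4-fold lower number (0.81 log units; beyond the scatter) from compound 1 to compound 2 and a 2.2-fold lower number (0.35 log units; beyond the scatter) from compound 3 to compound 4, 2.9-fold (0.46 log units) apart, beyond the scatter of two such steps. Seen from the other side, carboxy in place of ethoxycarbonyl gives a 3.2-fold higher number from compound 2 to compound 4 (0.50 log units; beyond the scatter) among the 2-fluorophenyl compounds, whereas the same exchange made no difference beyond the scatter among the 3-fluorophenyl compounds: the same change on two cores in this assay, a 1.1-fold higher number (0.04 log units; within the scatter) from compound 1 to compound 3 and a 3.2-fold higher number (0.50 log units; beyond the scatter) from compound 2 to compound 4, 2.9-fold (0.46 log units) apart, beyond the scatter of two such steps. The two changes therefore do not simply add up in this small set, and a step seen on one core gave the right direction but not a dependable size on the other, although this rests on just four compounds in one cell assay and does not show why the steps differ.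

The compounds shown leave open whether the fluorine matters at all, since a plain phenyl on the same carbonyl carbon would give the baseline for both fluorinated rings. They also leave open whether the gap between the steps would persist with chlorine in place of fluorine, or on a core carrying a primary amide in place of the carboxy group.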